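Working notes: ethoxy in place of naphthalen-2-yl

The source may report more compounds than this note shows. Statements on the series, on what has been measured and on what is new or still open speak of the compounds shown alone.

Compound 1 `COc1ccc(CSc2nnc(-c3cc(OC)c(OC)c(OC)c3)n2-c2ccc(OC)cc2)cc1`: 41100 nM
Compound 2 `COc1ccc(-n2c(SCC(=O)c3ccccc3)nnc2-c2cc(OC)c(OC)c(OC)c2)cc1`: 16200 nM
Compound 3 `COc1ccc(-n2c(SCC(=O)c3ccc4ccccc4c3)nnc2-c2cc(OC)c(OC)c(OC)c2)cc1`: > 60000 nM, a limit and not a number

All three were tested in a functional assay on HepG2 cells (Homo sapiens) for inhibition, read by MTT assay, with a stated time of 48 h; on this read-out lower numbers stand for stronger inhibition and higher numbers for weaker inhibition. Compound 3 stands only at the limit of > 60000 nM in this assay, at which 1 of the 3 values shown sits.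

Compound 4 `CCOC(=O)CSc1nnc(-c2cc(OC)c(OC)c(OC)c2)n1-c1ccc(OC)cc1` is not yet measured. It differs from compound 3 by ethoxy in place of naphthalen-2-yl on a carbonyl carbon, with ethoxy in place of naphthalen-2-yl on a carbonyl carbon.

The closest measured change at this place is an at least 3.7-fold higher number from compound 2 to compound 3 (0.56 log units; beyond the scatter), with naphthalen-2-yl in place of phenyl on a carbonyl carbon. Also relevant are a 2.5-fold lower number from compound 1 to compound 2 (0.40 log units; beyond the scatter) and an at least 1.4-fold higher number from compound 1 to compound 3 (0.16 log units; that floor lies within the scatter). Among the measured compounds shown here, no measured compound carries ethoxy, so the size of the step remains uncertain.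

Without naphthalen-2-yl, compound 4 is expected to resemble compound 2 at 16200 nM and compound 1 at 41100 nM. A lower number is therefore expected in this assay, an estimated at least 2.2-fold lower number from compound 3 to compound 4 (0.34 log units; beyond the scatter). For compound 4 the estimate is 27000 nM, with an expected range of 11000 nM to 60000 nM.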

Compound 4, half-maximal inhibitory concentration: > 60000 nM
Compound 4: only a limit was reported (the forecaster's own chance of this, stated with the estimate: 15%); middle value at least 2.2-fold (0.34 log units) from the limit.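

In this assay compound 4 is reported only as a limit, and compound 3 sits at that same limit, leaving the step between them unreadable: the limit of > 60000 nM in this assay, at which 2 of the 4 values shown sit.

Replacing naphthalen-2-yl with ethoxy on this carbonyl carbon does not return the read-out to the level of the phenyl compound, as an at least 3.7-fold higher number from compound 2 to compound 4 (0.56 log units; beyond the scatter) shows, and phenyl is the only one of these three carbonyl groups to give a number rather than a limit. The comparison with the 4-methoxyphenyl compound is less informative, since in an at least 1.4-fold higher number from compound 1 to compound 4 (0.16 log units; that floor lies within the scatter) the floor does not separate the two.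

As far as these compounds go, how far compound 3 and compound 4 lie beyond the limit remains open. Also open, from the compounds shown here alone, is whether a carboxylic acid or a dimethylamino group on this carbonyl carbon would follow phenyl or ethoxy.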